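A few compounds are considered here, and "the series" means these few. Any claim that something is new, unique, unknown or untested is made for them only; others in the source may bear on it.

Measured so far:
compound 1 `N#C/C(=C\c1ccc(Cl)cc1)C(=O)c1ccc[nH]1` — 27000 nM
compound 2 `N#C/C(=C\c1ccco1)C(=O)NCc1ccc(Cl)c(Cl)c1` — 20000 nM

In a functional assay on MCF7 cells (Homo sapiens) for inhibition, read by MTT assay, with a stated time of 72 h (on this read-out lower numbers stand for stronger inhibition of growth and higher numbers for weaker inhibition of growth), compound 2 gives 20000 nM and compound 1 gives 27000 nM; the two numbers lie within the scatter of each other, so compound 2 is not set apart from compound 1. Compound 3 `N#C/C(=C\c1ccc(Cl)cc1)C(=O)NCc1ccc(Cl)c(Cl)c1` differs from compound 2 by 4-chlorophenyl in place of furan-2-yl on a double-bonded chain carbon bound to a double-bonded chain carbon. Going by the values given here, no step between measured compounds covers this change. Compound 1 already carries a 4-chlorophenyl and gives 27000 nM, so no step beyond the scatter is expected. The step from compound 2 to compound 3 is expected to be a 1.3-fold higher number from compound 2 to compound 3 (0.10 log units; within the scatter). Compound 3 is expected near 25000 nM, within 10000 nM to 60000 nM.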

Compound 3, concentration for 50% growth inhibition: 21000 nM
For compound 3 the middle estimate is 1.2-fold (0.08 log units) above the measured one; the range from low to high includes it.
By their numbers in this assay, from the lowest: compounds 2, 3 and 1 (each within the scatter of the next).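

In this assay the exchange of furan-2-yl for 4-chlorophenyl on a double-bonded chain carbon bound to a double-bonded chain carbon gives a 1.1-fold higher number from compound 2 to compound 3 (0.02 log units; within the scatter), so this position tolerates both aromatic rings with no readable change on the shared core. Nothing measured accounts for this flat result. Still open, going by these compounds, is whether an amine or a carboxylic acid on the ring at this position would give a step beyond the scatter, and whether a morpholine ring in place of the aromatic ring would do so.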